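Working notes on three measured compounds and one pending

The compounds below may be only part of what the source reports. "The series", "measured", "known", "first", "only" and "open" are said of these compounds alone.

Measured compounds in an assay on isolated protein for inhibition of 2-Hydroxyacid oxidase 2 (Homo sapiens), tested at 1 uM; on this read-out lower numbers stand for a weaker effect and higher numbers for a stronger effect at the one concentration tested:
- compound 1 `Cc1n[nH]c(C(=O)O)c1Cc1cccc(-c2ccc(OC(F)(F)F)cc2)c1`: 6%
- compound 2 `Cc1n[nH]c(C(=O)O)c1Cc1ccc(Oc2ccccc2)cc1`: 10%
- compound 3 `Cc1n[nH]c(C(=O)O)c1Cc1cccc(-c2ccccc2F)c1`: 5%

All three share the same core and differ only in the tail carried on the six-membered ring attached through the methylene. For the measured compounds named here, the three numbers lie close together; every gap between them is within the scatter of repeated measurements, so no compound can be called stronger or weaker than another. Compound 1 sits among them with compound 3 nearest and compound 2 furthest, both gaps within the scatter. Going by the values given here, none of the three pairs differs in a single place, so no step between measured compounds is available, and no trend with the nature of the tail can be drawn from these three.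

Compound 4 `Cc1n[nH]c(C(=O)O)c1Cc1cccc(-c2ccc(C(=O)O)cc2)c1` is the next analogue awaiting measurement in this assay . It differs from compound 1 in one place: carboxy in place of trifluoromethoxy on an aromatic carbon. Nothing in the measured set speaks to what a carboxy at this position does, since each measured tail is a different kind of substituent and all sit at the same low level.

The expectation for the step of a number 6 percentage points higher from compound 1 to compound 4 (within the scatter) is therefore for no change beyond the scatter, with a weak lean toward a higher number. For compound 4 the estimate in this assay is 12%, with a range from 0% to 35%.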

Compound 4, a percentage reported as inhibition, at one concentration (the size of the read-out at that concentration, not a potency): 3%
Compound 4: the middle estimate sits 9 percentage points above what was measured, within the range that was stated.
By their numbers in this assay, from the lowest: compounds 4, 3, 1 and 2 (each within the scatter of the next).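

In this assay, the series now has its first step between compounds that differ in one place: carboxy in place of trifluoromethoxy on an aromatic carbon gives a number 3 percentage points lower from compound 1 to compound 4 (within the scatter), so this exchange at this position does not separate the two compounds. The exchange brings in a hydrogen-bond donor where the group that leaves has none, and it lowers the heavy-atom count, yet the read-out stays at the low level shared by the whole set. No measured evidence bears on why the step is this small.

Going by these compounds, it remains open whether any other group on this aromatic carbon, such as an amine, a nitrile or a longer chain, would lift the read-out clear of this level, since a single exchange cannot show how the position responds in general. On these data alone, because this assay reports the effect at one concentration only, it also remains open whether compound 1 and compound 4 would differ in potency if tested across a range of concentrations.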